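A few compounds are considered here, and "the series" means these few. Any claim that something is new, unique, unknown or untested is made for them only; others in the source may bear on it.

Measured compounds:
compound 1, `CCCC/N=C(\NC#N)Nc1cccnc1` — 20 mg/kg
compound 2, `CCC(CC)/N=C(\NC#N)Nc1cccnc1` — 20 mg/kg

In a functional assay on the whole organism (blood, strain Wistar-Okamoto) with Rattus norvegicus as the target, with a stated time of 5 days (a lower number here means that less compound is needed, a higher number that more compound is needed for the effect), compound 1 gives 20 mg/kg. Compound 2 gives 20 mg/kg in this assay, so the single measured step, no change at the digits printed from compound 1 to compound 2 (within the scatter), lies within the scatter; compound 1 therefore stands level with compound 2 on the numbers shown, and there is no measured spread in the series to set a direction.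

Compound 3, `C=C(C)C/N=C(\NC#N)Nc1cccnc1`, differs from compound 1 in one place: 1-methylethenyl in place of propyl on a saturated chain carbon bound to a double-bonded nitrogen. Going by the values given here, the only step that bears on this one is the exchange of pentan-3-yl for butyl on the double-bonded nitrogen, which left this assay unchanged, no change at the digits printed from compound 1 to compound 2 (within the scatter). That step alters the chain on the same nitrogen, though not by the same group, and it gives no ground to expect movement beyond the scatter.

Compound 3 is therefore expected to give about 20 mg/kg in this assay, with a range from 10 mg/kg to 40 mg/kg, an estimated step of no change at the digits printed from compound 1 to compound 3 (within the scatter).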

Compound 3, minimum effective dose: 20 mg/kg
Estimate against measurement, compound 3: no gap at the digits printed; the measured number falls inside the stated range.
By their numbers in this assay, from the lowest: compounds 1, 2 and 3 (each within the scatter of the next).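

In this assay, 1-methylethenyl in place of propyl on a saturated chain carbon bound to a double-bonded nitrogen gives no change at the digits printed from compound 1 to compound 3 (within the scatter) and thereby shows that a double bond outside aromatic rings can enter this chain with no step beyond the scatter. The exchange of pentan-3-yl for 2-methylprop-2-en-1-yl on the double-bonded nitrogen gives no change at the digits printed from compound 2 to compound 3 (within the scatter) and extends the same reading to an unsaturated group set against a branched saturated one. No measured finding accounts for these results.

The three groups on this nitrogen are all hydrocarbon chains, so the series still has no direction of change in this read-out. On these data alone, whether an amine, a carboxylic acid or a much longer chain at this place would move the minimum effective dose beyond the scatter remains open.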